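The compounds below may be only part of what the source reports. "The series", "measured", "known", "first", "only" and "open" are said of these compounds alone.

Of the compounds shown here, three built on one shared core have been measured in a physicochemical assay for lipophilicity, read by HPLC, at pH 7.5; a higher number here means a more lipophilic compound, a lower number a more polar compound. Compound 1 `N#Cc1c(-c2ccc(Br)cc2)nc2cnccc2c1NCC(N)=O` gives 1.9. Compound 2 `CC[C@@H](Nc1c(C#N)c(-c2ccc(-c3cccc(OC)c3)cc2)nc2cnccc12)C(N)=O` gives 2.7, and compound 3 `CCOc1ccccc1-c1ccc(-c2nc3cnccc3c(N[C@@H]3CCOC3=O)c2C#N)cc1` gives 2.7. Compound 2 therefore stands level with compound 3 at the digits shown, the two together forming the top of the three numbers, while the gap down to compound 1 lies beyond the usual scatter of this assay.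

Compound 4 `CC[C@@H](Nc1c(C#N)c(-c2ccc(-c3ccccc3C(C)C)cc2)nc2cnccc12)C(N)=O` has not yet been measured. It differs from compound 2 in one place: 2-isopropylphenyl in place of 3-methoxyphenyl on an aromatic carbon. Going by the values given here, no pair of measured compounds differs by a single change of this kind, so the size of the step cannot be read off from the data and has to be expected. Since the group that leaves carries one hydrogen-bond acceptor and the group that enters carries none, with one more heavy atom, a rise in this assay beyond the scatter is expected. The expected step is a number 1.10 log units higher from compound 2 to compound 4 (beyond the scatter). Compound 4 is estimated at 3.8, with a range from 3.3 to 4.4.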

Compound 4, distribution coefficient: 3.5
Compound 4: middle estimate off by 0.30 log units, on the high side, within the range that was stated.
By their numbers in this assay, from the lowest: compound 1; then compounds 2 and 3 (each within the scatter of the next); then compound 4.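

In this assay, putting 2-isopropylphenyl in place of 3-methoxyphenyl on an aromatic carbon gives a number 0.80 log units higher from compound 2 to compound 4 (beyond the scatter) and provides the first reading of a single change among these compounds. It shows that this position, para to a large group, is one where exchanging the attached aromatic group alone can move the number clear of the usual scatter. The step combines several differences, since the substituent and its place on the ring both change, the hydrogen-bond acceptor is lost and a heavy atom is gained, and nothing available accounts for its size.

As far as these compounds go, how much each difference contributes remains open, and plain phenyl or 3-isopropylphenyl would help separate them. Also open, from the compounds shown here alone, is where the number would fall with an amine or a carboxylic acid on the ring at this position.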